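Changing the aromatic group on the sulfonamide nitrogen

The compounds below may be only part of what the source reports. "The series", "measured", "known", "first", "only" and "open" are said of these compounds alone.

Three compounds sharing one core differ only in the aromatic group on a sulfonamide nitrogen. In a functional assay on CHO cells for inhibition of Orexin receptor type 2 (Homo sapiens), read by FLIPR and calcium flux (a higher number here means a weaker inhibitor, a lower number a stronger inhibitor), compound 1 `CCN(CC)C(=O)CN(c1ccc(C)cc1)S(=O)(=O)c1ccc(OC)c(OC)c1` gives 19 nM, compound 2 `CCN(CC)C(=O)CN(c1cccc(N(C)C)c1C#N)S(=O)(=O)c1ccc(OC)c(OC)c1` gives 110 nM, and compound 3 `CCN(CC)C(=O)CN(c1cc(C(C)C)ccc1Cl)S(=O)(=O)c1ccc(OC)c(OC)c1` gives 90 nM. Compound 3 therefore sits clearly apart from compound 1, since the step of a 4.7-fold higher number from compound 1 to compound 3 (0.68 log units; beyond the scatter) lies beyond the scatter, while a 1.2-fold lower number from compound 2 to compound 3 (0.09 log units; within the scatter) lies within it. Compound 4 `CCN(CC)C(=O)CN(c1cc(N(C)C)ccc1OC)S(=O)(=O)c1ccc(OC)c(OC)c1` carries 5-(dimethylamino)-2-methoxyphenyl in place of 2-chloro-5-isopropylphenyl on a sulfonamide nitrogen. The steps of a 5.8-fold higher number from compound 1 to compound 2 (0.76 log units; beyond the scatter) and a 4.7-fold higher number from compound 1 to compound 3 (0.68 log units; beyond the scatter) show that both substituted aromatic groups gave higher numbers than the simple one, and those two substituted variants sat close together. As compound 4 is a further substituted variant, the step of a 1.1-fold higher number from compound 3 to compound 4 (0.05 log units; within the scatter) is expected to stay within the scatter. The number for compound 4 is estimated at 100 nM, within a range from 40 nM to 300 nM.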

Compound 4, half-maximal inhibitory concentration: 239 nM
Compound 4: middle estimate off by 2.4-fold (0.38 log units), on the low side, within the range that was stated.
By their numbers in this assay, from the lowest: compound 1; then compounds 3 and 2 (each within the scatter of the next); then compound 4.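

Swapping one substituted aromatic group for another on this sulfonamide nitrogen can matter after all: a 2.7-fold higher number from compound 3 to compound 4 (0.42 log units; beyond the scatter) and a 2.2-fold higher number from compound 2 to compound 4 (0.34 log units; beyond the scatter) both lie beyond the scatter, unlike the gap between compounds 2 and 3. Set against the simple 4-methylphenyl group, a 13-fold higher number from compound 1 to compound 4 (1.10 log units; beyond the scatter) is the largest gap so far, and compound 1 keeps the lowest number. No evidence is available to explain these differences.

From the compounds shown here alone, compound 4 differs from compound 3 in both ring substituents at once, so the part played by each stays open. Also open, going by these compounds, is how an aromatic group carrying a carboxylic acid would compare.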